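The compounds below may be only part of what the source reports. "The series", "measured", "known", "first", "only" and "open" are said of these compounds alone.

Measured so far:
Compound 1 `COc1cc(NC(C)CCCNC(=O)Nc2ccc(Br)cc2)c2ncccc2c1`: 23000 nM
Compound 2 `COc1cc(NC(C)CCCNC(=O)NNC(=O)Nc2ccc(C(F)(F)F)cc2)c2ncccc2c1`: 12000 nM

Both values come from a functional assay on SW-620 cells (Homo sapiens) for inhibition, read by MTT assay, with a stated time of 72 h (on this read-out lower numbers stand for stronger inhibition and higher numbers for weaker inhibition), and make up a very small set. Compound 1 at 23000 nM and compound 2 at 12000 nM lie within the scatter of each other, so neither can be ranked ahead of the other. The next compound to be tested is compound 3 `COc1cc(NC(C)CCCNC(=O)Nc2ccc(F)cc2)c2ncccc2c1`, which keeps the core of compound 1 and differs from it in one place. It carries fluoro in place of bromo on an aromatic carbon, para to a large group (fluoro in place of bromo on an aromatic carbon). The two measured compounds do not form a pair differing in one place, so the data offer no direct measure of a change like this one. With no such guide, no step beyond the scatter is expected in this assay, and the value of compound 1 remains the natural anchor. The estimated change is a 1.1-fold higher number from compound 1 to compound 3 (0.04 log units; within the scatter) and is expected to stay within the scatter. For compound 3 the expected value is 25000 nM in this assay, with 11000 nM to 55000 nM as the estimated range.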

Compound 3, half-maximal inhibitory concentration: 25000 nM
Compound 3: the middle estimate sits on the measured number at the digits printed; measured number inside the range.
By their numbers in this assay, from the lowest: compounds 2, 1 and 3 (each within the scatter of the next, the first and the last beyond it).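

In this assay, among the compounds shown here, the exchange of bromo for fluoro on an aromatic carbon, para to a large group, gives the first step in this set that can be read at a single place: a 1.1-fold higher number from compound 1 to compound 3 (0.04 log units; within the scatter). This step lies within the scatter, so the 4-bromophenyl and 4-fluorophenyl forms cannot be told apart in this assay, and this one exchange of halogen leaves the read-out at this position without a measurable difference. Nothing measured here offers an explanation for this result.

The compounds shown leave open whether a group other than these two halogens at the same position, such as an amine, a carboxylic acid or a longer alkyl chain, would give a step beyond the scatter. From the compounds shown here alone, compound 2 differs from compound 1 and compound 3 in more than one place, so what its trifluoromethyl group contributes on its own also remains open.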